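Swapping Furan for Phenyl on a Shared Nucleoside Core

The source may hold more compounds than are shown below. What is called first, only, known or untested is meant among the compounds shown, and "the series" means these compounds.

Compound 1 `Nc1nc(N)c2c(-c3cc4ccccc4o3)cn([C@@H]3O[C@H](CO)[C@@H](O)[C@H]3O)c2n1` carries a 1-benzofuran-2-yl group on the shared core, and in a functional assay on K562 cells (Homo sapiens), read by MTT assay, with a stated time of 72 h (a higher number here means a weaker inhibitor, a lower number a stronger inhibitor), compound 1 gives 18600 nM. Compound 2 `Nc1nc(N)c2c(-c3ccoc3)cn([C@@H]3O[C@H](CO)[C@@H](O)[C@H]3O)c2n1` bears furan-3-yl at the same place. In this assay compound 2 reaches only a limit of the assay, > 20000 nM, and not a number. Compound 3 `CN(C)c1ncnc2c1c(-c1cc3ccccc3o1)cn2[C@@H]1O[C@H](CO)[C@@H](O)[C@H]1O` likewise sits at a limit in this assay, > 20000 nM. Among the compounds with values here, the single step between measured compounds is an at least 1.0-fold higher number from compound 1 to compound 2 (0.03 log units; that floor lies within the scatter); because of the limit of > 20000 nM in this assay, at which 2 of the 3 values shown sit, its true size is unknown, and its floor lies within the scatter.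

Compound 4 `Nc1nc(N)c2c(-c3ccccc3)cn([C@@H]3O[C@H](CO)[C@@H](O)[C@H]3O)c2n1` is the compound not yet measured: phenyl in place of furan-3-yl on an aromatic carbon. Within the data shown here, no measured step involves phenyl, so only the limit of compound 2 and the weak number of compound 1 bear on the question. The account therefore expects no step beyond the scatter in this assay, with a step that the limit leaves unreadable from compound 2 to compound 4 as its estimate, and the most likely outcome is another limit rather than a number. Compound 4 is estimated at 25000 nM, in a range from 9000 nM to 70000 nM.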

Compound 4, half-maximal inhibitory concentration: > 20000 nM
Compound 4: a limit, no number (the forecaster's own chance of this, stated with the estimate: 65%); the middle value does not contradict the limit.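

In this assay, like compound 2, compound 4 gives > 20000 nM, which is a limit of the assay and not a number. Within the data shown here, with phenyl at this aromatic carbon, the comparison with the only number in the set gives an at least 1.0-fold higher number from compound 1 to compound 4 (0.03 log units; that floor lies within the scatter), so a six-membered aromatic ring of carbon only gives the same floor as the five-membered aromatic ring of furan-3-yl and shows no step beyond the scatter. The direct exchange of furan-3-yl for phenyl cannot be read, and the true size of the step from the 1-benzofuran-2-yl group remains unknown, because of the following: the limit of > 20000 nM in this assay, at which 3 of the 4 values shown sit.

As far as these compounds go, whether furan-3-yl and phenyl differ at all remains open, since the two groups can be told apart only by numbers that these compounds do not provide. From the compounds shown here alone, it is also open whether an amine, a carboxylic acid or a longer chain on this aromatic carbon of the shared core would give a number in this assay rather than another limit.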